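Pyridine Ring in Place of Halogenated Phenyl on the Sulfonyl

This account rests on a few compounds, and the source may have more. Where it says the series, first, only, none or still open, it means among the compounds named here.

Three measured compounds share one core and differ only in the aromatic ring attached to the sulfonyl sulfur. In a functional assay on DLD-1 cells (Homo sapiens) for antiproliferative activity, read by CellTiter-Glo, with a stated time of 72 h (a lower number here means a stronger inhibitor, a higher number a weaker inhibitor), compound 1 `CC1CCN(C2CCN(S(=O)(=O)c3ccc(C#N)cc3)CC2)CC1` gives 2800 nM. Compound 2 `Cc1cccc(S(=O)(=O)N2CCC(N3CCC(C)CC3)CC2)c1` gives 25 nM. Compound 3 `CC1CCN(C2CCN(S(=O)(=O)c3ccc(Br)c(Cl)c3)CC2)CC1` gives 12 nM, the lowest of the three numbers, with compound 2 nearest to it and compound 1 furthest away.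

The steps between them show how much this ring matters: a 230-fold lower number from compound 1 to compound 3 (2.37 log units; beyond the scatter), and a 110-fold lower number from compound 1 to compound 2 (2.05 log units; beyond the scatter), while a 2.1-fold lower number from compound 2 to compound 3 (0.32 log units; beyond the scatter).

Compound 4 `CC1CCN(C2CCN(S(=O)(=O)c3cncc(Br)c3)CC2)CC1` has not yet been measured. The change from compound 3 is 5-bromopyridin-3-yl in place of 4-bromo-3-chlorophenyl on a sulfonyl sulfur. Within the data shown here, none of the measured steps exchanges a ring carbon for a nitrogen or removes a chlorine on its own, so nothing in hand fixes the size of this step directly. The measured steps do show that a ring carrying halogens sits at the low end, while a ring carrying a nitrile sits far higher. Because the step of a 2.1-fold lower number from compound 2 to compound 3 (0.32 log units; beyond the scatter) was only modest, a ring that keeps one bromine is expected to stay in the lower region, with a modest rise in the number. Compound 4 is therefore expected to give about 40 nM, most likely between 10 nM and 200 nM, which would mean an expected step of a 3.3-fold higher number from compound 3 to compound 4 (0.52 log units; beyond the scatter).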

Compound 4, half-maximal inhibitory concentration: > 5000 nM
Compound 4: a limit, no number; the forecaster's own chance of this, stated with the estimate: 2%; middle value at least 120-fold (2.09 log units) away from the limit.
By their numbers in this assay, from the lowest: compound 3; then compound 2; then compound 1. At a limit, above all of these: compound 4.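

Compound 4 reaches no number in this assay, only a limit: the limit of > 5000 nM in this assay, at which 1 of the 4 values shown sits. Keeping a bromine on the ring is clearly not enough to hold the number low, as 5-bromopyridin-3-yl in place of the earlier rings gives an at least 410-fold higher number from compound 3 to compound 4 (2.61 log units; beyond the scatter) and an at least 200-fold higher number from compound 2 to compound 4 (2.30 log units; beyond the scatter), so compound 4 goes against the earlier impression that a halogen-bearing ring sits at the low end. The earlier compounds shown here singled out only the nitrile-bearing ring as a poor choice, whereas this bromine-bearing ring with a nitrogen also lands at the high end, with an at least 1.7-fold higher number from compound 1 to compound 4 (0.25 log units; that floor lies within the scatter), so the two cannot be told apart in this assay.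

This single change swaps a ring carbon for a nitrogen and also removes the chlorine, and the compounds shown leave open which of these carries the loss. A 3-bromophenyl ring on the sulfonyl sulfur would help to separate the two, and a pyridine ring carrying a methyl group instead of the bromine would show whether the ring nitrogen is poorly accepted with a different substituent.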